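A Sulfone Replaces the Hydroxyl of Compound 3

A few compounds are considered here, and "the series" means these few. Any claim that something is new, unique, unknown or untested is made for them only; others in the source may bear on it.

For the measured compounds named here, compound 3 `CCC(CC)CNc1c(C(N)=O)cnc2ccc(-c3ccc(CO)nc3)cc12` gives 87 nM in an assay on HT-29 cells for inhibition of Serine-protein kinase ATM (Homo sapiens), read by fluorescence, with a stated time of 1 h (a higher number here means a weaker inhibitor, a lower number a stronger inhibitor), the lowest of the three numbers measured so far: compound 1 `CCC(CC)CNc1c(C(N)=O)cnc2ccc(-c3ccncc3)cc12` gives 418 nM and compound 2 `CCC(CC)CNc1c(C(N)=O)cnc2ccc(-c3ccnnc3)cc12` gives 908 nM. The steps of a 4.8-fold lower number from compound 1 to compound 3 (0.68 log units; beyond the scatter) and a 10-fold lower number from compound 2 to compound 3 (1.02 log units; beyond the scatter) show that the 6-(hydroxymethyl)pyridin-3-yl ring produced the strongest inhibition among these, while a 2.2-fold higher number from compound 1 to compound 2 (0.34 log units; beyond the scatter) was modest. Compound 4 `CCC(CC)CNc1c(C(N)=O)cnc2ccc(-c3ccc(CS(C)(=O)=O)nc3)cc12` differs from compound 3 by methylsulfonyl in place of hydroxy on a saturated chain carbon bound to an aromatic carbon. Going by the values given here, no measured step alters this hydroxy group itself; the earlier steps concern the whole ring and bear on the change only indirectly. One therefore expects for compound 4 a step of a 1.7-fold higher number from compound 3 to compound 4 (0.24 log units; within the scatter) in this assay, toward a weaker inhibitor. Compound 4 is estimated at 150 nM, within a range from 50 nM to 450 nM.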

Compound 4, half-maximal inhibitory concentration in the Serine-protein kinase ATM assay: 39 nM
Compound 4: the middle estimate sits 3.8-fold (0.59 log units) above what was measured; measured number outside the range, below it.
By their numbers in the Serine-protein kinase ATM assay, from the lowest: compound 4; then compound 3; then compound 1; then compound 2.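

At this saturated chain carbon bound to an aromatic carbon, methylsulfonyl in place of hydroxy gives, in the Serine-protein kinase ATM assay, a 2.2-fold lower number from compound 3 to compound 4 (0.35 log units; beyond the scatter). The hydrogen-bond donor of the hydroxy group is therefore not needed for this level of inhibition, something the earlier whole-ring steps could not show. The same change also lowers the reading in a physicochemical assay for lipophilicity, using the shake flask method, measured as octanol-water partition, at pH 7.4; a lower number here means a more polar compound, a higher number a more lipophilic compound: the measured distribution coefficient of compound 3, 3.7, and of compound 4, 3.1, a number 0.60 log units lower (beyond the scatter) In the physicochemical assay compound 3 gives 3.7 and compound 4 gives 3.1.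

The compounds shown do not tell whether the sulfonyl oxygens or the added methyl carry the step. On these data alone, how an amine, a sulfonamide or a longer chain would fare on this carbon remains open.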